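Shortening the carbonate chain of an azidothymidine prodrug

A few compounds are considered here, and "the series" means these few. Any claim that something is new, unique, unknown or untested is made for them only; others in the source may bear on it.

Compound 2 `Cc1cn(C2CC(N=[N+]=[N-])C(COC(=O)OCCCCCCO)O2)c(=O)[nH]c1=O` holds the lowest number in an ADME assay for pharmacokinetics (a higher number here means that the compound lasts longer, a lower number that the compound disappears faster), giving 0.117 h. Compound 1 `Cc1cn(C2CC(N=[N+]=[N-])C(COC(=O)OCCCCO)O2)c(=O)[nH]c1=O` gives 0.5 h in this assay. Compound 3 `CCCCOC(=O)OCC1OC(n2cc(C)c(=O)[nH]c2=O)CC1N=[N+]=[N-]` differs from compound 2 by hydrogen in place of 2-hydroxyethyl on a saturated chain carbon, four bonds along the chain from an oxygen next to a carbonyl group. Among the measured compounds shown here, the only step that bears on it runs the other way along the same chain: a 4.3-fold lower number from compound 1 to compound 2 (0.63 log units; beyond the scatter), where growing the chain shortened the half-life. Cutting the chain back in compound 3 is therefore expected to raise the number, though the loss of the hydroxy leaves the size uncertain; the estimate is a 2.6-fold higher number from compound 2 to compound 3 (0.41 log units; beyond the scatter). Compound 3 is expected to give about 0.3 h in this assay, between 0.1 h and 1 h.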

Compound 3, half-life: 0.15 h
Beside the measured number, compound 3's estimate is 2.0-fold (0.30 log units) above it, and the stated range covers the measured number.
By their numbers in this assay, from the lowest: compounds 2 and 3 (each within the scatter of the next); then compound 1.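

In this assay, hydrogen in place of 2-hydroxyethyl gives a 1.3-fold higher number from compound 2 to compound 3 (0.11 log units; within the scatter), so removing those atoms at this position leaves the number level with that of compound 2. Hydrogen in place of the hydroxy of compound 1 gives a 3.3-fold lower number from compound 1 to compound 3 (0.52 log units; beyond the scatter), which shows that among these three compounds only compound 1 stands apart and that a shorter chain alone does not restore its number. Nothing available explains this result. On these data alone, it remains open whether an amine or a carboxylic acid in place of that hydroxy would keep the number of compound 1.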